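A Saturated Ring in Place of an Aromatic One

The source may hold more compounds than are shown below. What is called first, only, known or untested is meant among the compounds shown, and "the series" means these compounds.

Compound 2 `c1ccc(CCc2ccc3c(NCCCNCc4ccco4)ccnc3c2)cc1` has the lower of the two numbers measured in an ADME assay for permeability, using PAMPA, with a stated time of 30 min, at pH 7.4 (a lower number here means that the compound crosses the layer more slowly, a higher number that the compound crosses the layer faster), giving 23 10^-6 cm/s. Compound 1 `COc1cccc(CNCCCNc2ccnc3cc(-c4ccc(F)cc4)ccc23)c1O` gives 237 10^-6 cm/s in this assay, and the gap between the two lies beyond the usual scatter. Compound 3 `c1coc(CNCCCNc2ccnc3cc(CC4CCCCC4)ccc23)c1` has not yet been measured. Its difference from compound 2 is cyclohexyl in place of benzyl on a saturated chain carbon bound to an aromatic carbon. Going by the values given here, no measured pair shows how such a change plays out here, so the expected step of a 1.3-fold higher number from compound 2 to compound 3 (0.12 log units; within the scatter) is small and not beyond the scatter in either direction. Compound 3 is estimated at 30 10^-6 cm/s in this assay, with a range from 10 10^-6 cm/s to 90 10^-6 cm/s.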

Compound 3, apparent permeability: 23 10^-6 cm/s
Compound 3: the middle estimate sits 1.3-fold (0.12 log units) above what was measured; the measured number falls inside the stated range.
By their numbers in this assay, from the lowest: compounds 2 and 3 (each within the scatter of the next); then compound 1.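

Putting cyclohexyl in place of benzyl on a saturated chain carbon bound to an aromatic carbon gives no change at the digits printed from compound 2 to compound 3 (within the scatter) in this assay. This first matched pair shows that, here, an aromatic ring of carbon only and a non-aromatic one can be exchanged without a step beyond the scatter. Nothing at hand explains this result. Still open, as far as these compounds go, is whether an amine, a carboxylic acid or a longer chain at this place would move the number, and whether the same exchange would give the same result in another compound.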